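From a fluorobenzyl ether to an allyl ether

A few compounds are considered here, and "the series" means these few. Any claim that something is new, unique, unknown or untested is made for them only; others in the source may bear on it.

Compound 1, `CN(C)CCNc1ccnc2cc(OCc3ccc(F)cc3)ccc12`, in a functional assay on SK-OV-3 cells (Homo sapiens) for cytotoxicity, read by MTT assay, with a stated time of 48 h (on this read-out higher numbers stand for weaker inhibition and lower numbers for stronger inhibition), gives 890 nM.
Compound 2, `CCCCCCOc1ccc2c(Cl)ccnc2c1`, reaches only the assay limit of > 10000 nM in this assay.
Compound 3, `Clc1ccnc2cc(OCc3ccccc3)ccc12`, in this assay gives 5170 nM.

Compound 1 holds the lowest of the two numbers; compound 3 lies above it by a gap beyond the scatter, and compound 2 sits at a limit. Compound 4, `C=CCOc1ccc2c(NCCN(C)C)ccnc2c1`, differs from compound 1 by vinyl in place of 4-fluorophenyl on a saturated chain carbon bound to an oxygen on an aromatic ring. Going by the values given here, the one measured step at that position is an at least 1.9-fold lower number from compound 2 to compound 3 (0.28 log units; that floor lies within the scatter), which rests on the limit of > 10000 nM in this assay, at which 1 of the 3 values shown sits, and so only marks a floor. Compound 4 reverses that direction, a ring leaving and a short chain entering, so a higher number in this assay is expected, of uncertain size. Compound 4 is expected near 3000 nM, from 1000 nM to 10000 nM. This amounts to an expected 3.4-fold higher number from compound 1 to compound 4 (0.53 log units; beyond the scatter).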

Compound 4, half-maximal inhibitory concentration: 1560 nM
Estimate against measurement, compound 4: 1.9-fold (0.28 log units) above; the range from low to high includes it.
By their numbers in this assay, from the lowest: compounds 1 and 4 (each within the scatter of the next); then compound 3. At a limit, above all of these: compound 2.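

Vinyl in place of 4-fluorophenyl, on a saturated chain carbon bound to an oxygen on an aromatic ring, gives a 1.8-fold higher number from compound 1 to compound 4 (0.24 log units; within the scatter) in this assay. Going by these compounds alone, with the rest of compound 1 kept, the aromatic ring can therefore leave this place without a difference beyond the scatter, something the earlier compounds could not show. For compound 2, the earlier step at this place offered only a floor: the limit of > 10000 nM in this assay, at which 1 of the 4 values shown sits.

On these data alone, how a longer chain or an amine at this place would read on the core of compound 1 stays open. So does whether the fluorine contributes anything to the value of compound 1.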